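Ethyl to Methyl Across Two Aldosterone Synthase Scaffolds

The source may hold more compounds than are shown below. What is called first, only, known or untested is meant among the compounds shown, and "the series" means these compounds.

Compound 1 `CCC1c2cc(Cl)ccc2C(=O)N1c1cccnc1` was measured in an assay on cells for inhibition of cytochrome P450 11B2, mitochondrial (Homo sapiens), read by HTRF (on this read-out higher numbers stand for weaker inhibition and lower numbers for stronger inhibition), where compound 1 gives 121 nM. Its close relative compound 2 `CC1c2cc(Cl)ccc2C(=O)N1c1cccnc1` differs from it at a single place, a change that reads (hydrogen in place of methyl on a saturated chain carbon bound to a saturated ring carbon). In this assay compound 2 gives 123 nM, so the step of a 1.0-fold higher number from compound 1 to compound 2 (0.01 log units; within the scatter) amounts to essentially no movement at all.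

The second pair rests on a larger core. Compound 3 `CCC(=O)N[C@@H]1CCCc2c1cncc2N1C(=O)c2ccc(Cl)cc2[C@H]1CC` carries an amide-bearing saturated ring fused onto a pyridine; how the core of compound 3 differs from the core of compound 1 is not broken down here. In this assay compound 3 gives 90 nM, the lowest of the three numbers, though its gaps to compound 1 and compound 2 both sit within the scatter, so no order among the three can be stated.

Compound 4 `CCC(=O)N[C@@H]1CCCc2c1cncc2N1C(=O)c2ccc(Cl)cc2[C@H]1C` is the counterpart of compound 3 in the same sense that compound 2 is the counterpart of compound 1: the change is hydrogen in place of methyl on a saturated chain carbon bound to a saturated ring carbon. The place of the change is described in the same words for both pairs, so this is the same change as before. Because the earlier step of a 1.0-fold higher number from compound 1 to compound 2 (0.01 log units; within the scatter) was flat, the step from compound 3 to compound 4 is expected to be flat as well, a 1.1-fold higher number from compound 3 to compound 4 (0.02 log units; within the scatter). On that basis compound 4 is estimated at 95 nM in this assay, with a plausible range from 50 nM to 190 nM.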

Compound 4, half-maximal inhibitory concentration: 66 nM
Compound 4: the middle estimate sits 1.4-fold (0.16 log units) above what was measured, within the range that was stated.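

In this assay the change of ethyl to methyl gives a 1.4-fold lower number from compound 3 to compound 4 (0.13 log units; within the scatter) and so stays inside the usual spread of repeated measurements on the larger core, as it does on the smaller one. This does not show that the change is without any effect, since a small shift could go unseen within that spread, and two cores are too few to support a rule for the whole series. What can be said is that the change carried over from the core of compound 1 to the core of compound 3 without a step that can be told apart from the earlier one, and the two steps, set side by side, do not differ: the same change on two cores in this assay, a 1.0-fold higher number (0.01 log units; within the scatter) from compound 1 to compound 2 and a 1.4-fold lower number (0.13 log units; within the scatter) from compound 3 to compound 4, 1.4-fold (0.14 log units) apart, within the scatter of two such steps.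

The compounds shown leave open how far this tolerance extends on the saturated ring carbon, as only ethyl and methyl appear there, so a longer chain such as propyl or butyl, a hydroxymethyl group, an amine or a carboxylic acid could behave quite differently. They also leave open whether the same flat result would hold on any core beyond these two, or in any read-out other than this assay.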